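Amide coumarins: swapping the basic ring for an anilino tail

The compounds below may be only part of what the source reports. "The series", "measured", "known", "first", "only" and "open" are said of these compounds alone.

Among the measured compounds shown here, compound 1 `CC(C)=CCc1cc(C(=O)Nc2cc3ccc(OCCC4CCCCN4)c(C)c3oc2=O)ccc1O` is measured in a functional assay on SK-BR-3 cells (Homo sapiens) for antiproliferative activity (a lower number here means a stronger inhibitor, a higher number a weaker inhibitor), and gives 640 nM, the lower of the two numbers so far. Compound 2 `CCNCCCOc1ccc2cc(NC(=O)c3ccc(O)c(CC=C(C)C)c3)c(=O)oc2c1C` gives 720 nM, and the step of a 1.1-fold higher number from compound 1 to compound 2 (0.05 log units; within the scatter) lies within the scatter. Compound 3 `CC(C)=CCc1cc(C(=O)Nc2cc3ccc(OCCCN(C)c4ccccc4)c(C)c3oc2=O)ccc1O` is not yet measured; it differs from compound 1 in one place: (methyl(phenyl)amino)methyl in place of piperidin-2-yl on a saturated chain carbon, two bonds along the chain from an oxygen on an aromatic ring. For the measured compounds named here, only the step from compound 1 to compound 2 touches this position, and it moved little. The expected number for compound 3 is therefore near that of compound 1, around 900 nM with a range of 350 nM to 2500 nM, a step estimated as a 1.4-fold higher number from compound 1 to compound 3 (0.15 log units; within the scatter).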

Compound 3, half-maximal inhibitory concentration: > 50000 nM
Compound 3: no number, only a limit (the forecaster's own chance of this, stated with the estimate: 5%); middle value at least 55-fold (1.74 log units) away from the limit.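

The position accepts both the piperidin-2-yl ring and the open ethylamino chain, but it does not accept every amine tail: the methyl(phenyl)amino tail gives an at least 78-fold higher number from compound 1 to compound 3 (1.89 log units; beyond the scatter) and an at least 69-fold higher number from compound 2 to compound 3 (1.84 log units; beyond the scatter). Compound 3 gives only a limit, so these steps have no exact size: the limit of > 50000 nM in this assay, at which 1 of the 3 values shown sits.

Going from compound 1 to compound 3 adds a six-membered aromatic ring of carbon only and drops to 0 hydrogen-bond donors in one change, so these two differences remain unseparated. A dimethylamino tail would have no hydrogen-bond donor and no such ring, which would help to tell them apart.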